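Aryl swap on the triazole: compound 3 to compound 4

The compounds below may be only part of what the source reports. "The series", "measured", "known", "first", "only" and "open" are said of these compounds alone.

Measured compounds:
compound 1 `N#CC1=C(N)Oc2c(c3nc4ccccc4nc3c3ccccc23)C12C(=O)N(Cc1cnnn1-c1ccc(F)cc1)c1ccccc12` — in a functional assay on HCT-116 cells (Homo sapiens) for antiproliferative activity, read by MTT assay, with a stated time of 48 h (a lower number here means a stronger inhibitor, a higher number a weaker inhibitor), compound 1 gives > 50000 nM, which is a limit of the assay and not a number.
compound 2 `N#CC1=C(N)Oc2c(c3nc4ccccc4nc3c3ccccc23)C12C(=O)N(Cc1cnnn1-c1ccccc1Cl)c1ccccc12` — in this assay compound 2 gives > 50000 nM, again a limit and not a number.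
compound 3 `N#CC1=C(N)Oc2c(c3nc4ccccc4nc3c3ccccc23)C12C(=O)N(Cc1cnnn1-c1ccc(S(N)(=O)=O)cc1)c1ccccc12` — in this assay compound 3 gives 31200 nM.
compound 4 `Cc1ccc(Cl)cc1-n1nncc1CN1C(=O)C2(C(C#N)=C(N)Oc3c2c2nc4ccccc4nc2c2ccccc32)c2ccccc21` — not yet measured.

Going by the values given here, compound 3 holds the only number; the other two entries sit at the limit of > 50000 nM in this assay, at which 2 of the 3 values shown sit. From compound 3 to compound 4 the change is 5-chloro-2-methylphenyl in place of 4-sulfamoylphenyl on an aromatic nitrogen.

Among the compounds with values here, the steps that bear on this are the two that reach compound 3: an at least 1.6-fold lower number from compound 1 to compound 3 (0.20 log units; that floor lies within the scatter) and an at least 1.6-fold lower number from compound 2 to compound 3 (0.20 log units; that floor lies within the scatter). Within the data shown here, both floors lie within the scatter, so they say only that the sulfamoylphenyl compound is the one that reads a number while the halophenyl compounds read a limit. Compound 4 reverses that direction, exchanging the sulfamoylphenyl for a chloro-methylphenyl; the step from compound 3 to compound 4 is therefore expected to run toward a higher number, a 1.9-fold higher number from compound 3 to compound 4 (0.28 log units; within the scatter), with a real chance of a limit only. Compound 4 is estimated at 60000 nM, between 30000 nM and 150000 nM.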

Compound 4, half-maximal inhibitory concentration: > 50000 nM
Compound 4 gave a limit, no number; the forecaster's own chance of this, stated with the estimate: 65%; the middle value is on the limit's open side.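

In this assay, going by these compounds alone, 5-chloro-2-methylphenyl in place of 4-sulfamoylphenyl on the aromatic nitrogen gives an at least 1.6-fold higher number from compound 3 to compound 4 (0.20 log units; that floor lies within the scatter), so this step's floor adds no measurable size to the earlier steps. Within the data shown here, what the change does add is a third aryl group lacking the sulfamoyl, this one carrying both a chloro and a methyl group, that reads only a limit, leaving compound 3 as the sole compound with a number: the limit of > 50000 nM in this assay, at which 3 of the 4 values shown sit. The steps from compound 1 and compound 2 to compound 4 join two limits and cannot be read.

As far as these compounds go, how far compound 1, compound 2 and compound 4 lie from compound 3 remains open, as does any ranking among those three. Also open, from the compounds shown here alone, is whether an amine or a carboxylic acid in the place of the sulfamoyl group would read a number in this assay.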